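A few compounds are considered here, and "the series" means these few. Any claim that something is new, unique, unknown or untested is made for them only; others in the source may bear on it.

Measured so far in a functional assay on Hs68 cells (Homo sapiens) for cytotoxicity; a higher number here means that more compound is tolerated, a lower number that less compound is tolerated:

compound 1 `O=C(NCc1ccc(Br)cc1)c1ccc2cnccc2n1` with 10 ug/mL
compound 2 `CC(C)(C)Oc1ccccc1CNC(=O)c1ccc2cnccc2n1` with 4.4 ug/mL

Of these two numbers, compound 2 has the lower, and its gap to compound 1 lies beyond the usual scatter. Compound 3 `O=C(NCc1ccccc1)c1ccc2cnccc2n1` has not yet been measured in this assay and differs from compound 2 in one place: hydrogen in place of tert-butoxy on an aromatic carbon of a six-membered aromatic ring of carbon only, ortho to a large group. Within the data shown here, no measured pair shows this change on its own, so any forecast is loose. Among the measured compounds shown here, the only guide is compound 1, which also lacks tert-butoxy and gives 10 ug/mL in the same test of tolerance. A step towards a higher number is therefore expected, moderate in size and probably beyond the scatter. The estimate amounts to a 2.7-fold higher number from compound 2 to compound 3 (0.44 log units; beyond the scatter), though the expected size remains uncertain. For compound 3 the expected value is 12 ug/mL, with an estimated range from 5 ug/mL to 35 ug/mL.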

Compound 3, half-maximal cytotoxic concentration: 71 ug/mL
For compound 3 the middle estimate is 5.9-fold (0.77 log units) below the measured one, outside the stated range (above it).
By their numbers in this assay, from the lowest: compound 2; then compound 1; then compound 3.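

In this assay, among these compounds, putting hydrogen in place of tert-butoxy on an aromatic carbon of a six-membered aromatic ring of carbon only, ortho to a large group, gives a 16-fold higher number from compound 2 to compound 3 (1.21 log units; beyond the scatter) and provides the first direct reading of this change. Hydrogen in place of bromo on an aromatic carbon points the same way, with a 7.1-fold higher number from compound 1 to compound 3 (0.85 log units; beyond the scatter), so among these three compounds the one without either group, compound 3, has the highest number, and none of the three goes against this. Nothing measured alongside these numbers accounts for the size of either step.

The compounds shown compare only tert-butoxy and bromo with hydrogen, so they cannot tell whether any group on this ring lowers the number or whether these two are particular cases. Methoxy, fluoro, an amine or a carboxylic acid on the same aromatic carbon would help to settle this, and it remains open whether any of them could keep the number as high as that of compound 3.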